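The compounds below may be only part of what the source reports. "The series", "measured", "known", "first", "only" and "open" are said of these compounds alone.

Measured compounds:
compound 1 `CCCCCCCCn1cc(/C=C/C(=O)c2ccc(NC(=O)CN3CCN(c4ccccc4)CC3)cc2)nn1` gives 52400 nM
compound 2 `O=C(CN1CCC(Cc2ccccc2)CC1)Nc1ccc(C(=O)/C=C/c2cn(Cc3ccc(Br)cc3)nn2)cc1` gives 40000 nM
compound 3 `CCCCCCCCCCn1cc(/C=C/C(=O)c2ccc(NC(=O)CN3CCN(c4ccccc4)CC3)cc2)nn1` gives 52100 nM

All three numbers come from a functional assay on A549 cells (Homo sapiens) for inhibition, read by MTT assay; on this read-out lower numbers stand for stronger inhibition and higher numbers for weaker inhibition. Among the compounds with values here, compound 1 stands at the highest of the three numbers, yet its nearest neighbour is compound 3 and the one step that joins them, a 1.0-fold lower number from compound 1 to compound 3 (0.00 log units; within the scatter), is within the scatter; compound 2 sits within the scatter of compound 1 as well. On the numbers shown, the three compounds cannot be told apart in this assay.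

Compound 4 `CCCCCCCCn1cc(/C=C/C(=O)c2ccc(NC(=O)CN3CCN(C(=O)OC(C)(C)C)CC3)cc2)nn1` has not yet been measured. It differs from compound 1 in one place: tert-butoxycarbonyl in place of phenyl on an amine nitrogen in a ring. The shared core, the chain on the aromatic nitrogen and the amide linkage are kept; what changes is the group on the ring nitrogen.

Within the data shown here, no measured step in the set touches this part of the molecule. The step from compound 1 to compound 3 changes only the chain length and is within the scatter, and compound 2 differs from compound 1 in several places at once, so the values of compound 1 and compound 2 can only be set side by side. Among the measured compounds shown here, there is therefore no measured step from which a direction for the exchange of phenyl for tert-butoxycarbonyl can be read, and the expectation for compound 4 rests on the narrow spread of the whole set.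

Given that spread, compound 4 is expected to stay in the same region, with an expected step of a 1.0-fold higher number from compound 1 to compound 4 (0.02 log units; within the scatter). The estimate for compound 4 is 55000 nM, with a range from 20000 nM to 150000 nM; the range is wide since no shown step informs this change.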

Compound 4, half-maximal inhibitory concentration: 43300 nM
For compound 4 the middle estimate is 1.3-fold (0.10 log units) above the measured one; measured number inside the range.
By their numbers in this assay, from the lowest: compounds 2, 4, 3 and 1 (each within the scatter of the next).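

Within the data shown here, the step on the ring nitrogen in this assay is a 1.2-fold lower number from compound 1 to compound 4 (0.08 log units; within the scatter) and gives the first reading at this position. Phenyl, with its six-membered aromatic ring and no hydrogen-bond acceptors, and tert-butoxycarbonyl, with no ring and two hydrogen-bond acceptors, cannot be told apart in this pair, so for compound 1 and compound 4 an aromatic ring on this nitrogen is not needed to keep the number in the same region. Nothing available accounts for this outcome.

Still open, going by these compounds, is whether any group on this ring nitrogen, such as a plain hydrogen, an acetyl group or a chain ending in a carboxylic acid, would move the number beyond the scatter. Also open, on these data alone, is whether tert-butoxycarbonyl would give the same picture alongside the longer chain of compound 3 on the aromatic nitrogen, or with a much shorter chain such as methyl there.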